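From (pyrrolidin-2-yl)methyl to 1-methylpiperidin-3-yl on the amide

This account rests on a few compounds, and the source may have more. Where it says the series, first, only, none or still open, it means among the compounds named here.

Measured so far in a physicochemical assay for solubility, at pH 7.4; a lower number here means a less soluble compound, a higher number a more soluble compound:
- compound 1 `O=C(N[C@H]1CN(S(=O)(=O)c2ccccc2)C[C@@H]1C(=O)N[C@H]1CCCNC1)c1cc(-c2ccccc2Cl)on1` at 12000 nM
- compound 2 `O=C(N[C@H]1CN(S(=O)(=O)c2ccccc2)C[C@@H]1C(=O)NC[C@@H]1CCCN1)c1cc(-c2ccccc2Cl)on1` at 503000 nM

Of the two numbers, compound 2 holds the higher. Compound 3 `CN1CCC[C@H](NC(=O)[C@H]2CN(S(=O)(=O)c3ccccc3)C[C@@H]2NC(=O)c2cc(-c3ccccc3Cl)on2)C1`, not yet measured, carries 1-methylpiperidin-3-yl in place of (pyrrolidin-2-yl)methyl on an amide-type nitrogen. Among the measured compounds shown here, one measured step bears on this: a 42-fold higher number from compound 1 to compound 2 (1.62 log units; beyond the scatter) was large and replaced piperidin-3-yl with (pyrrolidin-2-yl)methyl. The new change moves back to a piperidin-3-yl group, now with a methyl whose own step is unmeasured, so a large drop is expected in this assay for this pair. The estimate means a 13-fold lower number from compound 2 to compound 3 (1.10 log units; beyond the scatter) as the expected step. The value expected for compound 3 is 40000 nM (estimated range 9000 nM to 200000 nM).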

Compound 3, solubility: 503000 nM
Beside the measured number, compound 3's estimate is 13-fold (1.10 log units) below it; the whole stated range lies below it.
By their numbers in this assay, from the lowest: compound 1; then compounds 2 and 3 (each within the scatter of the next).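

In this assay, methyl in place of hydrogen on the amine nitrogen in the ring gives a 42-fold higher number from compound 1 to compound 3 (1.62 log units; beyond the scatter), so the piperidin-3-yl ring on the amide-type nitrogen does not by itself keep the number low. The exchange of (pyrrolidin-2-yl)methyl for 1-methylpiperidin-3-yl gives no change at the digits printed from compound 2 to compound 3 (within the scatter), so two different groups at this place reach the same number. Nothing available explains either step. Still open, on these data alone, is whether an ethyl or an acetyl group on that ring nitrogen would match methyl. As far as these compounds go, whether methyl on the pyrrolidine nitrogen would alter the number is also open.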